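Swapping Phenyl for Trifluoromethyl in a Growth Inhibition Series

This account rests on a few compounds, and the source may have more. Where it says the series, first, only, none or still open, it means among the compounds named here.

In a functional assay on CAKI-1 cells (Homo sapiens) for inhibition, read by sulforhodamine B assay, with a stated time of 48 h, tested at 10 uM (on this read-out lower numbers stand for less inhibition of growth and higher numbers for more inhibition of growth at the one concentration tested), compound 1 (`CC(=O)c1cccc(Nc2ccnc(SCC(=O)c3ccc(-c4ccccc4)cc3)n2)c1`) gives 23%, and compound 2 (`CC(=O)c1ccc(Nc2ccnc(SCC(=O)c3ccc(-c4ccccc4)cc3)n2)cc1`) gives 16%, so the two lie within the scatter of each other. Compound 3 (`CC(=O)c1cccc(Nc2ccnc(SCC(=O)c3ccc(C(F)(F)F)cc3)n2)c1`) carries trifluoromethyl in place of phenyl on an aromatic carbon. Among the compounds with values here, the only measured step, a number 7 percentage points lower from compound 1 to compound 2 (within the scatter), swaps 3-acetylphenyl for 4-acetylphenyl elsewhere in the molecule, so it bears only weakly on this change. No step beyond the scatter is therefore expected, and the expected step is a number 3 percentage points lower from compound 1 to compound 3 (within the scatter). The estimate for compound 3 is 20%, with an expected range of 5% to 38%.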

Compound 3, percent growth inhibition at one concentration: 42%
Compound 3: middle estimate off by 22 percentage points, on the low side, outside the stated range (above it).
By their numbers in this assay, from the lowest: compounds 2 and 1 (each within the scatter of the next); then compound 3.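

In this assay, within the data shown here, the group on this aromatic carbon matters more than the earlier compounds could show: trifluoromethyl in place of phenyl gives a number 19 percentage points higher from compound 1 to compound 3 (beyond the scatter), the only step so far that clears the scatter. In this one pair, the phenyl ring is therefore not needed for growth inhibition at this position, as a group with no ring gives the higher number. Nothing measured here explains why this swap raises the number. Still open, from the compounds shown here alone, is how a methyl group or an amine on this carbon would compare with trifluoromethyl, and whether the same swap would raise the number for compound 2 with its 4-acetylphenyl group.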